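A pyrimidin-5-yl exchange on the shared core

A few compounds are considered here, and "the series" means these few. Any claim that something is new, unique, unknown or untested is made for them only; others in the source may bear on it.

Measured so far in a physicochemical assay for solubility, in phosphate buffer, at pH 7.4; a lower number here means a less soluble compound, a higher number a more soluble compound:
Compound 1 `CCNC(=O)Nc1nc2cc(-c3cccnc3)c(=O)n(CC3CC3)c2s1`: 5000 nM
Compound 2 `CCNC(=O)Nc1nc2cc(-c3cncnc3)c(=O)n(C(C)C)c2s1`: 7000 nM

Only these two compounds have numbers, and they differ in more than one place, so no single structural change can be read from them. Compound 2 stands at 7000 nM, and compound 1 at 5000 nM lies within the scatter of it, so this assay does not separate them.

The unmeasured compound 3 `CCNC(=O)Nc1nc2cc(-c3cncc(OC)c3)c(=O)n(C(C)C)c2s1` keeps the isopropyl group of compound 2 and differs in one place: 5-methoxypyridin-3-yl in place of pyrimidin-5-yl on an aromatic carbon. Within the data shown here, no measured pair isolates this change, so the expectation is only loosely anchored. Compound 1, at 5000 nM, gives the one other level available. A modest step to a lower number is expected, not far beyond the scatter. The estimate amounts to a 2.3-fold lower number from compound 2 to compound 3 (0.37 log units; beyond the scatter), and a wide margin is expected around it. For compound 3 the expected value is 3000 nM, with an estimated range from 1000 nM to 7000 nM.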

Compound 3, solubility: < 5000 nM
Compound 3: only a limit was reported (the forecaster's own chance of this, stated with the estimate: 5%); the middle value lies beyond the limit too.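

Among these compounds, the exchange of pyrimidin-5-yl for 5-methoxypyridin-3-yl on an aromatic carbon, with the isopropyl group kept, is the first change at this position that can be read on its own, and in this assay it gives an at least 1.4-fold lower number from compound 2 to compound 3 (0.14 log units; that floor lies within the scatter). Compound 3 is reported only as a limit, < 5000 nM, and not as a number. The step is therefore only a floor, and its true size cannot be read, nor whether it lies beyond the scatter, because the reading of compound 3 ends at a limit: the limit of < 5000 nM in this assay, at which 1 of the 3 values shown sits.

The compounds shown leave open where compound 3 actually stands in this assay, and whether the step belongs to the methoxy group or to the change from two ring nitrogens to one, as no compound here separates the two. Also open, from the compounds shown here alone, is how this position would read in this assay with a different group on the same pyridin-3-yl ring, such as an amine or a carboxylic acid in place of the methoxy group.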